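A few compounds are considered here, and "the series" means these few. Any claim that something is new, unique, unknown or untested is made for them only; others in the source may bear on it.

Compound 1 `CO[C@]1(CO)O[C@H](CO)[C@@H](O)[C@@H]1O` returns only a limit in a functional assay, with a stated time of 30 min; a higher number here means a weaker inhibitor, a lower number a stronger inhibitor: for compound 1 the read-out is > 30000 nM. Compound 2 `CC(=O)OCC1=C[C@H](O)[C@@H]2C(C(=O)O)=CO[C@@H](O[C@H]3O[C@@H](CO)[C@H](O)[C@@H](O)[C@@H]3O)[C@H]12` likewise returns only a limit in this assay, compound 2 giving > 30000 nM. Both therefore sit at the limit of > 30000 nM in this assay, at which 2 of the 2 values shown sit, so compound 1 stands at the weak end of what this assay can report. Compound 3 `CO[C@@]1(CO)O[C@H](CO)[C@@H](O)[C@@H]1O` is not yet measured. (the two compounds have the same atoms and bonds and differ only in configuration as drawn: 1 of 4 stereo elements differ; a stereocentre at a saturated ring carbon is drawn R in compound 1 and S in compound 3). Among the measured compounds shown here, no measured step between compounds is available here; the step that the limit leaves unreadable from compound 1 to compound 3 is expected to be none beyond the scatter. Compound 3 is expected near 60000 nM, within 20000 nM to 300000 nM, most likely reported again as a limit.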

Compound 3, half-maximal inhibitory concentration: > 30000 nM
Compound 3 was reported as a limit; the forecaster's own chance of this, stated with the estimate: 90%; the middle value is on the limit's open side.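

No step can be read from compound 1 to compound 3 in this assay, because both values are limits: the limit of > 30000 nM in this assay, at which 3 of the 3 values shown sit.

The compounds shown leave open whether the configuration at that saturated ring carbon affects inhibition at all.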